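Phenoxy for phenyl at the assay limit

A few compounds are considered here, and "the series" means these few. Any claim that something is new, unique, unknown or untested is made for them only; others in the source may bear on it.

compound 1 `CC(C)(C)OC(=O)N1CCC[C@H]1COCCCCCCCCC/C=C/c1ccc(Oc2ccccc2)cc1` gives > 100000 nM (a limit)
compound 2 `Cc1ccc([S+]([O-])N2CCC[C@H]2COCCCCCCCCC/C=C/c2ccc(-c3ccccc3)cc2)cc1` gives > 100000 nM (a limit)

In a functional assay on PANC-1 cells (Homo sapiens) for inhibition, read by XTT assay, with a stated time of 72 h (on this read-out lower numbers stand for stronger inhibition and higher numbers for weaker inhibition), compound 2 gives > 100000 nM which is a limit and not a number. Among the measured compounds shown here, the record so far holds the limit of > 100000 nM in this assay, at which 2 of the 2 values shown sit, and no step between measured compounds. Compound 3 `Cc1ccc([S+]([O-])N2CCC[C@H]2COCCCCCCCCC/C=C/c2ccc(Oc3ccccc3)cc2)cc1` departs from compound 2 with phenoxy in place of phenyl on an aromatic carbon on an aromatic carbon, para to a large group. Compound 1 also carries phenoxy and gives > 100000 nM which is likewise a limit. No shift beyond the scatter is therefore expected in this assay and the estimated a number no higher from compound 2 to compound 3 (the limit leaves the size open) is small. Compound 3 is estimated at 100000 nM with an expected range (30000 nM to 300000 nM).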

Compound 3, half-maximal inhibitory concentration: > 100000 nM
Compound 3 was reported as a limit; the forecaster's own chance of this, stated with the estimate: 70%; the middle value sits exactly at the limit.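

Compound 3, like compound 1 and compound 2, is reported only as a limit in this assay, so no step among them can be read: the limit of > 100000 nM in this assay, at which 3 of the 3 values shown sit.

The compounds shown leave open how phenoxy compares with phenyl in this assay.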